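Replacing benzylamino on a carbonyl carbon

The source may hold more compounds than are shown below. What is called first, only, known or untested is meant among the compounds shown, and "the series" means these compounds.

Compound 1 `CC1=CC[C@H]2[C@H](CC[C@]2(C)O)C(C)(C)[C@@H]1CC[C@H]1[C@]2(C)CC[C@H](OC(=O)c3ccc(Cl)cc3)C(C)(C)O[C@H]2CC[C@@]1(C)O`: 24100 nM
Compound 2 `CC1=CC[C@H]2[C@H](CC[C@]2(C)O)C(C)(C)[C@@H]1CC[C@H]1[C@]2(C)CC[C@H](OC(=O)NCc3ccccc3)C(C)(C)O[C@H]2CC[C@@]1(C)O`: 24500 nM

Among the compounds with values here, compound 2 stands level with compound 1, the only other compound measured in a functional assay on MCF7 cells (Homo sapiens) for antiproliferative activity, read by MTT assay, with a stated time of 72 h; a higher number here means a weaker inhibitor, a lower number a stronger inhibitor. Compound 3 `CC1=CC[C@H]2[C@H](CC[C@]2(C)O)C(C)(C)[C@@H]1CC[C@H]1[C@]2(C)CC[C@H](OC(=O)c3ccc(C(F)(F)F)cc3)C(C)(C)O[C@H]2CC[C@@]1(C)O` differs from it by 4-(trifluoromethyl)phenyl in place of benzylamino on a carbonyl carbon, with 4-(trifluoromethyl)phenyl in place of benzylamino on a carbonyl carbon. Within the data shown here, one measured step bears on this place: a 1.0-fold higher number from compound 1 to compound 2 (0.01 log units; within the scatter), with benzylamino in place of 4-chlorophenyl. That step stayed within the scatter, so no change beyond the scatter is expected, although a single step is slim evidence. The expected step is a 1.0-fold lower number from compound 2 to compound 3 (0.01 log units; within the scatter). For compound 3 the estimated value is 24000 nM, with an expected range from 12000 nM to 45000 nM.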

Compound 3, half-maximal inhibitory concentration: 23400 nM
Estimate against measurement, compound 3: 1.0-fold (0.01 log units) above; the measured number falls inside the stated range.
By their numbers in this assay, from the lowest: compounds 3, 1 and 2 (each within the scatter of the next).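

At this carbonyl carbon, 4-(trifluoromethyl)phenyl in place of benzylamino gives a 1.0-fold lower number from compound 2 to compound 3 (0.02 log units; within the scatter) in this assay and trifluoromethyl in place of chloro on an aromatic carbon gives a 1.0-fold lower number from compound 1 to compound 3 (0.01 log units; within the scatter) here. The position thus tolerates the loss of the hydrogen-bond donor counted on benzylamino, and neither change moves the number beyond the scatter. Nothing available accounts for this level result. The compounds shown leave open whether an amine or a carboxylic acid on the aromatic ring, or a longer chain between the carbonyl carbon and that ring, would move the number.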